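Aryl sulfone anilides as K-ATP channel inhibitors: working notes

The compounds below may be only part of what the source reports. "The series", "measured", "known", "first", "only" and "open" are said of these compounds alone.

Measured so far:
compound 1 `CC(O)(C(=O)Nc1ccc(S(=O)(=O)c2cccc(Cl)c2)cc1)C(F)(F)F` — 10000 nM
compound 2 `CC(O)(C(=O)Nc1ccc(S(=O)(=O)c2cnccn2)cc1)C(F)(F)F` — 12000 nM

Both values come from a functional assay (Cavia porcellus) with sulfonylurea receptors; K-ATP channels (Homo sapiens) as the target; on this read-out higher numbers stand for weaker inhibition and lower numbers for stronger inhibition. Among the compounds with values here, compound 2 has the highest number of the two, but its nearest neighbour is compound 1, and the only measured step, a 1.2-fold higher number from compound 1 to compound 2 (0.08 log units; within the scatter), lies within the scatter; the two compounds cannot be told apart on this read-out.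

Compound 3 `CC(O)(C(=O)Nc1ccc(S(=O)(=O)c2nccs2)cc1)C(F)(F)F` is not yet measured. It differs from compound 2 by 1,3-thiazol-2-yl in place of pyrazin-2-yl on a sulfonyl sulfur. Within the data shown here, the one measured step that bears on this position, swapping a 3-chlorophenyl for a pyrazin-2-yl on the sulfonyl sulfur, produced no movement beyond the scatter. With no other evidence, the expected step of a 1.2-fold lower number from compound 2 to compound 3 (0.08 log units; within the scatter) from the thiazol-2-yl is none beyond the scatter. Compound 3 is therefore estimated at 10000 nM, with a range from 4000 nM to 30000 nM.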

Compound 3, half-maximal inhibitory concentration: 1400 nM
The estimate for compound 3 lay 7.1-fold (0.85 log units) above the measured number, and the stated range ends above it.
By their numbers in this assay, from the lowest: compound 3; then compounds 1 and 2 (each within the scatter of the next).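

In this assay the group on the sulfonyl sulfur does matter: 1,3-thiazol-2-yl in place of pyrazin-2-yl gives an 8.6-fold lower number from compound 2 to compound 3 (0.93 log units; beyond the scatter) and in place of 3-chlorophenyl gives a 7.1-fold lower number from compound 1 to compound 3 (0.85 log units; beyond the scatter) at the same place. The earlier pair, each with a six-membered aromatic ring, had suggested a flat position, but that picture now holds only for those two groups, and the five-membered 1,3-thiazol-2-yl stands apart from both. Nothing on hand indicates why this change moves the number.

The compounds shown leave open whether the step follows the five-membered ring as such or its sulfur atom, a question that a 1,3-oxazol-2-yl or a thiophen-2-yl on the sulfonyl sulfur could address. Also open, on these data alone, is whether substituents on the 1,3-thiazol-2-yl, such as a methyl group or an amine, keep or lose the step.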